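Methyl in place of phenol hydrogen: a small expected step

The source may hold more compounds than are shown below. What is called first, only, known or untested is meant among the compounds shown, and "the series" means these compounds.

Compound 1 `N#Cc1ncn(-c2ccc(F)cc2)c1/N=C/c1ccc(O)cc1` and compound 2 `COc1ccc(/C=N/c2c(C#N)ncn2-c2ccc(F)cc2)cc1` share one core, and compound 2 differs from compound 1 only by methyl in place of hydrogen on an oxygen on an aromatic ring. In a functional assay on MDA-MB-231 cells (Homo sapiens) for antiproliferative activity, read by MTT assay, with a stated time of 48 h (on this read-out higher numbers stand for weaker inhibition and lower numbers for stronger inhibition), compound 1 gives 16300 nM, while compound 2 gives 17100 nM, so that a 1.0-fold higher number from compound 1 to compound 2 (0.02 log units; within the scatter). Compound 3 `COc1ccc(/C=N/c2c(C#N)ncn2Cc2ccc(F)cc2)cc1O` gives 2670 nM in this assay; how its core differs from the core of compound 1 is not broken down here. Compound 4 `COc1ccc(/C=N/c2c(C#N)ncn2Cc2ccc(F)cc2)cc1OC` has not yet been measured. It differs from compound 3 by methyl in place of hydrogen on an oxygen on an aromatic ring, the same change, at a place described in the same words, as that from compound 1 to compound 2. Since that earlier change left the number essentially unchanged, the step expected here is a 1.1-fold higher number from compound 3 to compound 4 (0.04 log units; within the scatter), resting on the fact that the same change gave a 1.0-fold higher number from compound 1 to compound 2 (0.02 log units; within the scatter). Compound 4 is therefore estimated at 2900 nM, expected to fall between 1200 nM and 7500 nM.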

Compound 4, half-maximal inhibitory concentration: 10500 nM
For compound 4 the middle estimate is 3.6-fold (0.56 log units) below the measured one; measured number outside the range, above it.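

In this assay, methyl in place of hydrogen on an oxygen on an aromatic ring gave a 3.9-fold higher number from compound 3 to compound 4 (0.59 log units; beyond the scatter), which means weaker inhibition on this core, whereas the same change left the number essentially unchanged on the core of compound 1. The two steps do not agree: the same change on two cores in this assay, a 1.0-fold higher number (0.02 log units; within the scatter) from compound 1 to compound 2 and a 3.9-fold higher number (0.59 log units; beyond the scatter) from compound 3 to compound 4, 3.7-fold (0.57 log units) apart, beyond the scatter of two such steps. This shows that the hydroxy to methoxy change does not carry over with the same size between these two cores, but it does not show which difference between the cores is responsible, and two pairs set no rule for the whole series.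

As far as these compounds go, what an ethyl group on that oxygen, or an amine in place of the hydroxy group, would do on either core stays open.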